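A few compounds are considered here, and "the series" means these few. Any claim that something is new, unique, unknown or untested is made for them only; others in the source may bear on it.

Measured compounds:
compound 1 `N#C[C@]1(O)[C@H](O)[C@@H](CO)O[C@@H](n2ccc(O)nc2=O)[C@@H]1O` in a functional assay on HeLa cells (Homo sapiens) (a lower number here means a stronger inhibitor, a higher number a weaker inhibitor), gives > 500000 nM.
compound 2 `Cc1cn([C@@H]2O[C@H](CO)[C@@H](O)[C@@](O)(C#N)[C@H]2O)c(=O)nc1O` in this assay gives > 500000 nM.
compound 3 `N#C[C@H]1[C@@H](O)[C@H](n2ccc(O)nc2=O)O[C@H](CO)[C@H]1O` in this assay gives 811000 nM.

The value of compound 1 in this assay is a limit of the assay and not a number. The value of compound 2 is likewise a limit. Going by the values given here, compound 3 gives the only number in the set; the other two values are limits, and both of them sit at the limit of > 500000 nM in this assay, at which 2 of the 3 values shown sit.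

The change from compound 1 to compound 2 is methyl in place of hydrogen on an aromatic carbon. The step that the two limits leave unreadable from compound 1 to compound 2 has limits at both ends, so its size cannot be read.

Compound 4 `Cc1cn([C@@H]2O[C@H](CO)[C@@H](O)[C@@H](C#N)[C@H]2O)c(=O)nc1O` is not yet measured. It differs from compound 3 by methyl in place of hydrogen on an aromatic carbon, which is the same change as that from compound 1 to compound 2, at a place described in the same words. The difference between the core of compound 3 and the core of compound 1 is not broken down here.

With the step from compound 1 to compound 2 unreadable, the expectation for compound 4 rests on the value of compound 3 in this assay and on the small size of the change. Compound 4 is expected to move by about a 1.0-fold lower number from compound 3 to compound 4 (0.01 log units; within the scatter) in this assay, close to no change. Compound 4 is therefore estimated at 800000 nM, between 300000 nM and 3000000 nM, with a fair chance that this assay reports only a limit for it.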

Compound 4, half-maximal inhibitory concentration: > 750000 nM
Compound 4: only a limit was reported (the forecaster's own chance of this, stated with the estimate: 60%); the middle value lies beyond the limit too.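

In this assay compound 4 gives > 750000 nM, which is a limit of the assay and not a number. No size can therefore be read for the change from compound 3 to compound 4. The compounds shown leave open whether methyl in place of hydrogen on an aromatic carbon shifts the value at all, on either the core of compound 1 or the core of compound 3.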